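A few compounds are considered here, and "the series" means these few. Any claim that something is new, unique, unknown or untested is made for them only; others in the source may bear on it.

Working notes on the series around the shared core of compound 3. In an in vitro functional assay on 1321-N1 cells for antagonist activity at transient receptor potential cation channel subfamily V member 1 (Homo sapiens), read by FLIPR and calcium flux (on this read-out lower numbers stand for stronger inhibition and higher numbers for weaker inhibition), compound 1 `CC(C)(C)c1ccc(NC(=O)c2ccc(-c3ccccn3)cc2)cc1` gives 42 nM, compound 2 `CC(C)(C)c1ccc(NC(=O)C2=CCN(c3ncccc3C(F)(F)F)CC2)cc1` gives 6 nM, and compound 3 `CC(C)(C)c1ccc(NC(=O)C2=CCN(c3ccccn3)CC2)cc1` gives 27 nM. For the measured compounds named here, compound 3 stands second highest of the three numbers; its gap to compound 1 lies within the scatter, and the only step beyond the scatter is a 4.5-fold higher number from compound 2 to compound 3 (0.65 log units; beyond the scatter), a modest change following loss of the trifluoromethyl. Compound 4 `CC(C)(C)c1ccc(NC(=O)C2=CCN(c3ccccc3F)CC2)cc1` carries 2-fluorophenyl in place of pyridin-2-yl on an amine nitrogen in a ring. Going by the values given here, no measured step bears on this ring exchange; the one known step concerns a substituent, not the ring itself. For compound 4 the number in this assay is therefore expected to stay within the scatter of compound 3, a 1.1-fold lower number from compound 3 to compound 4 (0.03 log units; within the scatter). Compound 4 is estimated at 25 nM, with a range from 8 nM to 80 nM.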

Compound 4, half-maximal inhibitory concentration: 265 nM
Beside the measured number, compound 4's estimate is 11-fold (1.03 log units) below it, outside the stated range (above it).
By their numbers in this assay, from the lowest: compound 2; then compounds 3 and 1 (each within the scatter of the next); then compound 4.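

The ring on this amine nitrogen is not interchangeable: in this assay, 2-fluorophenyl in place of pyridin-2-yl gives a 9.8-fold higher number from compound 3 to compound 4 (0.99 log units; beyond the scatter), whereas the earlier step concerned only a substituent on the ring. The exchange removes the ring nitrogen, with its one hydrogen-bond acceptor, and adds a fluorine, and this single step cannot separate the two changes. No measurement on hand explains the step.

Open, going by these compounds, is how a plain phenyl on the same nitrogen would read, which would separate the two changes. Also open, on these data alone, is whether a 2-chlorophenyl would read like 2-fluorophenyl.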